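Chloroanilino pyrimidine nitriles: ring substitution and growth inhibition

This account rests on a few compounds, and the source may have more. Where it says the series, first, only, none or still open, it means among the compounds named here.

Measured compounds in a functional assay on ECa-109 cells (Homo sapiens) for inhibition, read by MTT assay, with a stated time of 72 h; on this read-out higher numbers stand for weaker inhibition and lower numbers for stronger inhibition:
compound 1 `C#CCSc1nc(Nc2ccccc2Cl)c(C#N)c(-c2ccccc2)n1` gives > 128000 nM, which is a limit of the assay and not a number.
compound 2 `C#CCSc1nc(Nc2ccc(Cl)cc2)c(C#N)c(-c2ccccc2)n1` gives > 128000 nM, likewise a limit of the assay.
compound 3 `N#Cc1c(Nc2ccccc2Cl)nc(SCc2cn(Cc3ccccc3Cl)nn2)nc1-c1ccccc1` gives 28500 nM, the only number in the set.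

The series is a set of substituted pyrimidine nitriles with a chloroanilino group on the core. Compound 1 and compound 2 share one core; compound 3 carries a larger group on the sulfur, and the difference between the two cores is not broken down here. Going by the values given here, compound 3 is the only compound with a readable value in this assay; the two values of the first pair are limits, as noted in the limit of > 128000 nM in this assay, at which 2 of the 3 values shown sit.

Compound 1 and compound 2 differ in one place: 4-chlorophenyl in place of 2-chlorophenyl on a nitrogen on an aromatic ring. The step that the two limits leave unreadable from compound 1 to compound 2 cannot be read, since both values sit at the same limit.

Compound 4 `N#Cc1c(Nc2ccc(Cl)cc2)nc(SCc2cn(Cc3ccccc3Cl)nn2)nc1-c1ccccc1` is not yet measured. It stands to compound 3 as compound 2 stands to compound 1: 4-chlorophenyl in place of 2-chlorophenyl on a nitrogen on an aromatic ring. This is the same change at the same place. The measured pair gives no size for it, so the expectation for compound 4 rests on compound 3 alone. The step from compound 3 to compound 4 is expected to be small, a 1.2-fold higher number from compound 3 to compound 4 (0.09 log units; within the scatter), with wide uncertainty because of the unreadable a step that the two limits leave unreadable from compound 1 to compound 2. Compound 4 is therefore estimated at 35000 nM in this assay, within 10000 nM to 128000 nM.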

Compound 4, half-maximal inhibitory concentration: 1420 nM
Beside the measured number, compound 4's estimate is 25-fold (1.39 log units) above it; the measured number lies below the stated range.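

In this assay, on the core with the larger group on the sulfur, 4-chlorophenyl in place of 2-chlorophenyl gives a 20-fold lower number from compound 3 to compound 4 (1.30 log units; beyond the scatter), a large step on this core. On the core of compound 1 the same change cannot be read, since compound 1 and compound 2 both stand at a limit of the assay and not at numbers, so that pair neither supports nor contradicts the step: the limit of > 128000 nM in this assay, at which 2 of the 4 values shown sit. The series therefore shows one readable step on one core, and it does not show that the change carries over from one core to the other, or that its size depends on the core.

The compounds shown leave open whether the step belongs to chlorine in particular, since the only groups on that nitrogen are 2-chlorophenyl and 4-chlorophenyl, and a methoxy group or a bromine in place of the chlorine would test this. Also open, as far as these compounds go, is whether the step holds on a third core, for example one with a plain benzyl on the sulfur, and whether it appears in any read-out other than this assay.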